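A benzyl ester in place of the primary amide

The source may report more compounds than this note shows. Statements on the series, on what has been measured and on what is new or still open speak of the compounds shown alone.

Within the data shown here, the three compounds measured so far share one core and differ only in the side chain of the amino acid ester. In a functional assay on the whole organism (Tail, strain ICR) with Mus musculus as the target, in the tail flick test, with a stated time of 90 min, at a dose of 25 umol/kg by the oral route (on this read-out lower numbers stand for a weaker effect and higher numbers for a stronger effect at the one dose given), compound 1 `O=C(CN(c1ncnc2c1ncn2C1CCCCO1)C1CC1)N[C@@H](CCC(=O)OCc1ccccc1)C(=O)OCc1ccccc1` gives 25.2%. Compound 2 `O=C(CN(c1ncnc2c1ncn2C1CCCCO1)C1CC1)N[C@@H](CO)C(=O)OCc1ccccc1` gives 32.2% in this assay, and compound 3 `NC(=O)C[C@H](NC(=O)CN(c1ncnc2c1ncn2C1CCCCO1)C1CC1)C(=O)OCc1ccccc1` gives 35%. Compound 3 holds the highest of the three numbers, but its steps to the others, a number 9.8 percentage points higher from compound 1 to compound 3 (within the scatter) and a number 2.8 percentage points higher from compound 2 to compound 3 (within the scatter), both lie within the scatter, so no order among the three can be claimed.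

Compound 4 `O=C(CN(c1ncnc2c1ncn2C1CCCCO1)C1CC1)N[C@@H](CC(=O)OCc1ccccc1)C(=O)OCc1ccccc1` differs from compound 3 in one place: benzyloxy in place of amino on a carbonyl carbon. The step that bears on this is a number 9.8 percentage points higher from compound 1 to compound 3 (within the scatter), in which carbamoyl replaced (benzyloxycarbonyl)methyl and the number rose only within the scatter. The change from compound 3 to compound 4 reverses that kind of exchange, so a step of similar small size in the opposite direction is expected, a number 8 percentage points lower from compound 3 to compound 4 (within the scatter), which would not reach beyond the scatter. Compound 4 is therefore estimated at 27% in this assay, with a range from 15% to 40%.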

Compound 4, a percentage reported as activity, at one dose (the size of the read-out at that dose, not a potency): 25.1%
The estimate for compound 4 lay 1.9 percentage points above the measured number, and the stated range covers the measured number.
By their numbers in this assay, from the lowest: compounds 4, 1, 2 and 3 (each within the scatter of the next).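

In this assay, benzyloxy on a carbonyl carbon brings in a six-membered aromatic ring of carbon only and takes away a hydrogen-bond donor, yet this exchange for amino gives only a small step (a number 9.9 percentage points lower from compound 3 to compound 4 (within the scatter)), so the read-out does not separate the benzyl ester from the primary amide. Among these compounds, the same side chain also stays within the scatter against the hydroxy compound (a number 7.1 percentage points lower from compound 2 to compound 4 (within the scatter)) and, in a comparison of chain length that the earlier compounds did not offer, against the (benzyloxycarbonyl)methyl compound (a number 0.1 percentage points lower from compound 1 to compound 4 (within the scatter)). Nothing measured here explains these results.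

From the compounds shown here alone, it remains open whether a carboxylic acid or an amine on this side chain, or a longer chain carrying the ester, would move the number beyond the scatter. The four compounds shown cannot be ranked against one another.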